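The source may report more compounds than this note shows. Statements on the series, on what has been measured and on what is new or still open speak of the compounds shown alone.

Compound 1 `CC(C)N(Cc1cccc(OCCCCCC(=O)O)c1)C(=O)c1ccc(-c2cccc(OCc3ccccc3)c2)cc1` carries a benzyloxy group on its shared core. In an ADME assay on HEK293 cells (Homo sapiens) for cytotoxicity, read by CellTiter-Glo and resazurin assay, with a stated time of 72 h (a higher number here means that more compound is needed for the effect, a lower number that less compound is needed), compound 1 gives > 26000 nM, which is a limit of the assay rather than a number. Two further compounds share the same core. Compound 2 `CC(C)N(Cc1cccc(OCCCCCC(=O)O)c1)C(=O)c1ccc(-c2cc3ccccc3n2S(=O)(=O)c2ccccc2)cc1` returns > 26000 nM in this assay, again a limit. Compound 3 `CC(C)N(Cc1cccc(OCCCCCC(=O)O)c1)C(=O)c1ccc(-c2cccc(C(F)(F)F)c2)cc1`, with trifluoromethyl in place of benzyloxy on an aromatic carbon, also gives only a limit, > 26000 nM. The step that the two limits leave unreadable from compound 1 to compound 3 cannot be read in size, as shown by the limit of > 26000 nM in this assay, at which 3 of the 3 values shown sit.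

Among the compounds with values here, compound 4 `CC(C)N(Cc1cccc(OCCCCCC(=O)O)c1)C(=O)c1ccc(-c2cccc(Cl)c2)cc1` is the compound not yet measured. chloro in place of benzyloxy on an aromatic carbon Of the measured steps, only the one running from compound 1 to compound 3 bears on this change, as it too removes the benzyloxy group, and its size is not readable. Within the data shown here, there is thus no measured step from which a direction or a size could be taken, and all three known values sit at the same limit.

Compound 4 is therefore expected to sit at the limit as well, and the estimated step that the limit leaves unreadable from compound 1 to compound 4 is taken as none beyond the scatter. The estimate for compound 4 in this assay is 40000 nM, within a range from 20000 nM to 100000 nM.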

Compound 4, half-maximal effective concentration: > 21900 nM
Compound 4: only a limit was reported; the forecaster's own chance of this, stated with the estimate: 85%; the middle value does not contradict the limit.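

In this assay compound 4 gives > 21900 nM, which is a limit and not a number. Within the data shown here, no step to compound 4 from compound 1 or compound 3 can be read in size. The compounds shown leave open at what concentration any of them reaches the half-maximal effect, and whether exchanging these groups changes that concentration at all.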